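A phenyl for methoxymethyl on the carbonyl aryl ring

A few compounds are considered here, and "the series" means these few. Any claim that something is new, unique, unknown or untested is made for them only; others in the source may bear on it.

Of the compounds shown here, three built on one shared core have been measured in a functional assay on WI-38 VA13 cells (Homo sapiens) for cytotoxicity; on this read-out lower numbers stand for an effect already at smaller amounts and higher numbers for an effect only at larger amounts of compound. Compound 1 `Cc1c(C(=O)c2ccc(F)c(F)c2)oc2cc(-c3ccccc3)cc(O)c12` gives 0.4 ug/mL. Compound 2 `COCc1ccccc1C(=O)c1oc2cc(-c3ccccc3)cc(O)c2c1C` gives 0.1 ug/mL, the lowest of the two numbers available, the nearest being compound 1, with the step of a 4.0-fold lower number from compound 1 to compound 2 (0.60 log units; beyond the scatter) lying beyond the scatter. Compound 3 `Cc1c(C(=O)c2ccc(N(C)C)cc2)oc2cc(-c3ccccc3)cc(O)c12` reaches only a limit of this assay, > 4 ug/mL. The steps of an at least 10-fold higher number from compound 1 to compound 3 (1.00 log units; beyond the scatter) and an at least 40-fold higher number from compound 2 to compound 3 (1.60 log units; beyond the scatter) both run up to the limit (the limit of > 4 ug/mL in this assay, at which 1 of the 3 values shown sits), so their true size is not known.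

Compound 4 `Cc1c(C(=O)c2ccccc2-c2ccccc2)oc2cc(-c3ccccc3)cc(O)c12` is not yet measured. It differs from compound 2 by phenyl in place of methoxymethyl on an aromatic carbon. Within the data shown here, no measured step replaces a methoxymethyl with a phenyl; the two known steps change the aryl ring on the carbonyl carbon in other ways, one modest and one large, and compound 4 keeps a substituent at the same place ortho to a large group as compound 2 does. The step of a 2.0-fold higher number from compound 2 to compound 4 (0.30 log units; within the scatter) is therefore expected to stay within or only just beyond the scatter. For compound 4 the estimated value in this assay is 0.2 ug/mL, within a range from 0.05 ug/mL to 0.8 ug/mL.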

Compound 4, half-maximal effective concentration: 0.1 ug/mL
For compound 4 the middle estimate is 2.0-fold (0.30 log units) above the measured one, within the range that was stated.
By their numbers in this assay, from the lowest: compounds 2 and 4 (each within the scatter of the next); then compound 1. At a limit, above all of these: compound 3.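

Replacing methoxymethyl with phenyl on the aromatic carbon ortho to a large group gives no change at the digits printed from compound 2 to compound 4 (within the scatter) in this assay and so leaves compounds 2 and 4 indistinguishable on this read-out. The earlier compounds shown here showed only that exchanging one whole substituted aryl ring on the carbonyl carbon for another could move the number; this pair shows that, at this one place, a flexible chain with an oxygen and a six-membered aromatic ring of carbon only can stand in for each other, although the entering group is larger and brings no oxygen. Nothing measured here gives a reason why the two groups read alike.

The compounds shown carry only these two groups at this place, so it remains open how an amine, a carboxylic acid or a longer chain there would read. Equally open, going by these compounds, is whether a small group such as methyl or fluorine at this place would give a number like those of compounds 2 and 4, or one well apart from them.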